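The compounds below may be only part of what the source reports. "The series", "measured", "known", "first", "only" and "open" are said of these compounds alone.

Measured compounds in a functional assay on Caco-2 cells (Homo sapiens) for cytotoxicity, with a stated time of 48 h; on this read-out lower numbers stand for stronger inhibition and higher numbers for weaker inhibition:
Compound 1 `O=[N+]([O-])c1ccc(CN2CCC(n3cc(CC(OCc4cc(-c5ccc(Br)cc5)no4)c4ccc(Br)cc4)nn3)CC2)cc1` gives 3000 nM.
Compound 2 `N#Cc1ccc(-c2cc(COC(Cc3cn(C4CCN(Cc5ccc([N+](=O)[O-])cc5)CC4)nn3)c3ccc(Br)cc3)on2)cc1` gives 2000 nM.
Compound 3 `N#Cc1cccc(-c2cc(COC(Cc3cn(C4CCN(Cc5ccc([N+](=O)[O-])cc5)CC4)nn3)c3ccc(Br)cc3)on2)c1` gives 3000 nM.

Compound 3 stands level with compound 1 at the digits shown, and its nearest neighbour in this assay is compound 1, with no change at the digits printed from compound 1 to compound 3 (within the scatter). Going by the values given here, its step from compound 2, a 1.5-fold higher number from compound 2 to compound 3 (0.18 log units; within the scatter), also stays within the scatter, as does a 1.5-fold lower number from compound 1 to compound 2 (0.18 log units; within the scatter), so the three numbers form a flat set in which no compound can be called stronger or weaker than another.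

Compound 4 `O=[N+]([O-])c1ccc(CN2CCC(n3cc(CC(OCc4cc(-c5ccccc5Br)no4)c4ccc(Br)cc4)nn3)CC2)cc1` differs from compound 3 in one place: 2-bromophenyl in place of 3-cyanophenyl on an aromatic carbon. Among the compounds with values here, the steps that bear on this are the two that already exchanged the group on that aromatic carbon, no change at the digits printed from compound 1 to compound 3 (within the scatter) and a 1.5-fold higher number from compound 2 to compound 3 (0.18 log units; within the scatter), neither of which moved the number beyond the scatter. On that ground compound 4 is expected to stay close to compound 3 in this assay, with no step beyond the scatter, so that no change at the digits printed from compound 3 to compound 4 (within the scatter) is the estimated change. Compound 4 is thus expected to give about 3000 nM, in a range from 1200 nM to 8000 nM.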

Compound 4, half-maximal inhibitory concentration: 3000 nM
Estimate against measurement, compound 4: no gap at the digits printed; the measured number falls inside the stated range.
By their numbers in this assay, from the lowest: compounds 2, 1, 3 and 4 (each within the scatter of the next).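

The series now holds 2-bromophenyl alongside 4-bromophenyl, 4-cyanophenyl and 3-cyanophenyl on the aromatic carbon next to the ring nitrogen, and in this assay the latest exchange shows no change at the digits printed from compound 3 to compound 4 (within the scatter) for this change. The comparisons with the other two groups show no change at the digits printed from compound 1 to compound 4 (within the scatter) and a 1.5-fold higher number from compound 2 to compound 4 (0.18 log units; within the scatter) on the same carbon, so a bromo-bearing phenyl placed differently from that of compound 1 still leaves all four compounds in one flat set with no order among them. No further data bear on this result.

On these data alone, all four groups at this carbon are phenyl rings carrying bromo or cyano, so it remains open whether a phenyl carrying an amine or a carboxylic acid, or a plain alkyl chain in place of the phenyl, would stay in the same range. The same question stands for an amine in place of the nitro group elsewhere on the shared core.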